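A few compounds are considered here, and "the series" means these few. Any claim that something is new, unique, unknown or untested is made for them only; others in the source may bear on it.

Measured so far in a functional assay on CHO-K1 cells for agonist activity at Glucose-dependent insulinotropic receptor (Homo sapiens), read by cAMP accumulation and immunoassay, with a stated time of 1 h; a higher number here means a larger maximal response, a lower number a smaller maximal response:
- compound 1 `COC(=O)N1CCC(Oc2cc(Oc3cccc(/C=C4\SC(=O)NC4=O)c3)ncn2)CC1`: 33.7%
- compound 2 `CCOC(=O)N1CCC(Oc2cc(Oc3cccc(/C=C4\SC(=O)NC4=O)c3)ncn2)CC1`: 43.3%
- compound 3 `CC(C)(C)OC(=O)N1CCC(Oc2cc(Oc3cccc(/C=C4\SC(=O)NC4=O)c3)ncn2)CC1`: 78.3%

Compound 3 stands highest of the three numbers in this assay; its nearest neighbour is compound 2, a number a number 35 percentage points higher from compound 2 to compound 3 (beyond the scatter), and the furthest is compound 1, a number a number 44.6 percentage points higher from compound 1 to compound 3 (beyond the scatter), both beyond the scatter. Compound 1 and compound 2 differ by a number 9.6 percentage points higher from compound 1 to compound 2 (within the scatter), which lies within the scatter.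

Compound 4 `CC(C)COC(=O)N1CCC(Oc2cc(Oc3cccc(/C=C4\SC(=O)NC4=O)c3)ncn2)CC1` is not yet measured. It differs from compound 3 in one place: isobutyl in place of tert-butyl on an oxygen next to a carbonyl group.

For the measured compounds named here, two measured steps bear on this change, since both concern the group on the oxygen next to the carbonyl. The steps of a number 44.6 percentage points higher from compound 1 to compound 3 (beyond the scatter) and a number 35 percentage points higher from compound 2 to compound 3 (beyond the scatter) were both large and in the same direction, with the tert-butyl giving the highest number. Compound 4 keeps the same atoms as compound 3 but joins them as isobutyl, a chain rather than the branched tert-butyl. Going by the values given here, no measured pair shows a chain of this length, so the direction is uncertain; a fall back toward compound 2 cannot be excluded, nor a number close to compound 3. The expected outcome is a moderate step down, expressed as a number 18.3 percentage points lower from compound 3 to compound 4 (beyond the scatter). Compound 4 is therefore estimated at 60%, within a range from 40% to 85%.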

Compound 4, largest response reached (Emax), in percent of the reference or control that the assay uses: 62.4%
The estimate for compound 4 lay 2.4 percentage points below the measured number, and the stated range covers the measured number.
By their numbers in this assay, from the lowest: compounds 1 and 2 (each within the scatter of the next); then compound 4; then compound 3.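

In this assay, moving from tert-butyl to isobutyl on an oxygen next to a carbonyl group leaves the atoms unchanged but joins them differently, and this still gives a number 15.9 percentage points lower from compound 3 to compound 4 (beyond the scatter), so at this position the maximal response follows how the four carbons are joined and not only how many there are. Isobutyl nevertheless keeps much of the gain over the two smaller groups, with a number 19.1 percentage points higher from compound 2 to compound 4 (beyond the scatter) and a number 28.7 percentage points higher from compound 1 to compound 4 (beyond the scatter), which places compound 4 above compounds 1 and 2 but below compound 3 and shows that full branching is not needed for a number well clear of the methyl and ethyl compounds. The compounds shown come with no measurement that could account for the gap between the two isomers.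

From the compounds shown here alone, it remains open whether isopropyl, a straight butyl chain, a longer chain such as hexyl, or a ring such as cyclobutyl or phenyl would fall between these numbers or outside them. Also open is whether the same order among these groups would hold if an amide or urea nitrogen took the place of the oxygen next to the carbonyl group.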